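Chloro for Fluoro on a Second Core: Clearance Expectation

The compounds below may be only part of what the source reports. "The series", "measured", "known", "first", "only" and "open" are said of these compounds alone.

Measured so far:
compound 1, `CC(=O)N[C@@H]1CCC[C@H](C(=O)Nc2cc(-c3cnn4c3CCCC4)c(F)cn2)C1`, < 3 mL.min-1.g-1
compound 2, `CC(=O)N[C@@H]1CCC[C@H](C(=O)Nc2cc(-c3cnn4c3CCCC4)c(Cl)cn2)C1`, 17 mL.min-1.g-1
compound 3, `CC(=O)N[C@@H]1CCC[C@H](C(=O)Nc2cc(-c3cnn4c3CC(C)(C)C4)c(F)cn2)C1`, 19 mL.min-1.g-1

All three were run in an ADME assay on microsomes from liver (Homo sapiens) for metabolic stability; a higher number here means faster removal of the compound, a lower number slower removal. For compound 1 the value < 3 mL.min-1.g-1 is a limit of the assay and not a number. Compound 2 differs from compound 1 by chloro in place of fluoro on an aromatic carbon, and this gave an at least 5.6-fold higher number from compound 1 to compound 2 (0.75 log units; beyond the scatter). Compound 3 differs from compound 1 in its core by a group of 10 heavy atoms (8 carbon, 2 nitrogen; one five-membered non-aromatic ring with 1 hetero atom, one five-membered aromatic ring with 2 hetero atoms) in place of a group of 9 heavy atoms (7 carbon, 2 nitrogen; one five-membered aromatic ring with 2 hetero atoms, one six-membered non-aromatic ring with 1 hetero atom), on an aromatic carbon, which gave an at least 6.3-fold higher number from compound 1 to compound 3 (0.80 log units; beyond the scatter). Compound 4, `CC(=O)N[C@@H]1CCC[C@H](C(=O)Nc2cc(-c3cnn4c3CC(C)(C)C4)c(Cl)cn2)C1`, is not yet measured; it differs from compound 3 by chloro in place of fluoro on an aromatic carbon. This is the same kind of change as that from compound 1 to compound 2, though there the place is ortho to a group of 9 heavy atoms, while here it is ortho to a large group. Beside an at least 5.6-fold higher number from compound 1 to compound 2 (0.75 log units; beyond the scatter), compound 4 is expected to show a 1.7-fold higher number from compound 3 to compound 4 (0.23 log units; within the scatter) in this assay. A smaller step is expected because an at least 5.6-fold higher number from compound 1 to compound 2 (0.75 log units; beyond the scatter) begins at a limit, whereas compound 3 already stands at 19 mL.min-1.g-1. Compound 4 is therefore estimated at 32 mL.min-1.g-1, between 13 mL.min-1.g-1 and 75 mL.min-1.g-1.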

Compound 4, intrinsic clearance in microsomes: 50 mL.min-1.g-1
The estimate for compound 4 lay 1.6-fold (0.19 log units) below the measured number; the range from low to high includes it.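

In this assay, chloro in place of fluoro again gave a higher number on the core of compound 3, with a 2.6-fold higher number from compound 3 to compound 4 (0.42 log units; beyond the scatter), so the direction of the change held on both cores shown: the same change on two cores in this assay, an at least 5.6-fold higher number (0.75 log units; beyond the scatter) from compound 1 to compound 2 and a 2.6-fold higher number (0.42 log units; beyond the scatter) from compound 3 to compound 4; the limit leaves it open whether they differ

The change of core, made here with chloro in place, likewise gave a 2.9-fold higher number from compound 2 to compound 4 (0.47 log units; beyond the scatter), in the same direction as with fluoro: the same change on two cores in this assay, an at least 6.3-fold higher number (0.80 log units; beyond the scatter) from compound 1 to compound 3 and a 2.9-fold higher number (0.47 log units; beyond the scatter) from compound 2 to compound 4; the limit leaves it open whether they differ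

For compound 1 the value < 3 mL.min-1.g-1 is a limit of the assay and not a number, and two cores show only that the direction held, not that the size of the step carries over.

The compounds shown leave open how a methyl group or a nitrile would compare with chloro and fluoro in this place. They also leave open whether the step holds when the acetyl group gives way to a longer chain.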